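Ethyl for methyl on the sulfonamide of compound 2

The source may report more compounds than this note shows. Statements on the series, on what has been measured and on what is new or still open speak of the compounds shown alone.

Compound 2 `CC1(C)CC(NC(=S)Nc2ccc(Cl)cc2)c2cc(NS(C)(=O)=O)ccc2O1` gives 11600 nM in a functional assay on thoracic aorta (Rattus norvegicus) for inhibition; a lower number here means that less compound is needed, a higher number that more compound is needed for the effect. Compound 1 `CC1(C)CC(NC(=S)Nc2cccc(Cl)c2)c2cc(NS(C)(=O)=O)ccc2O1` gives 9800 nM and compound 3 `CC1(C)CC(NC(=O)Nc2ccc(C#N)cc2)c2cc(NS(C)(=O)=O)ccc2O1` gives 19800 nM; the number for compound 2 lies within the scatter of both, so the three measured compounds are not separated here. Within the data shown here, the only single-point step measured, a 1.2-fold higher number from compound 1 to compound 2 (0.07 log units; within the scatter), moves an aryl substituent and says nothing direct about the sulfonamide end. Compound 4 `CCS(=O)(=O)Nc1ccc2c(c1)C(NC(=S)Nc1ccc(Cl)cc1)CC(C)(C)O2` differs from compound 2 by methyl in place of hydrogen on a saturated chain carbon bound to a sulfonyl sulfur, a methanesulfonamido becoming an (ethylsulfonyl)amino. Among the measured compounds shown here, no measured step bears on this change, and no step in this set exceeds the scatter, so no shift beyond the scatter is expected, a 1.0-fold higher number from compound 2 to compound 4 (0.01 log units; within the scatter). Compound 4 is estimated at 12000 nM, expected between 5000 nM and 30000 nM.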

Compound 4, half-maximal effective concentration: 5100 nM
Compound 4: the middle estimate sits 2.4-fold (0.37 log units) above what was measured; the measured number falls inside the stated range.
By their numbers in this assay, from the lowest: compounds 4, 1, 2 and 3 (each within the scatter of the next, the first and the last beyond it).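

Methanesulfonamido to (ethylsulfonyl)amino gives a 2.3-fold lower number from compound 2 to compound 4 (0.36 log units; beyond the scatter) in this assay, so the sulfonamide end can move the number, if only modestly. Among these compounds, the earlier single-place step, 4-chlorophenyl in place of 3-chlorophenyl, stayed within the scatter, which makes this the first step to exceed it. Nothing available accounts for the shift. Going by these compounds, whether a propyl or longer chain on the sulfonyl continues this trend remains open. So does the outcome with isopropyl or phenyl there, and whether the gain carries over to ureas such as compound 3.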